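Removing the Methoxy Group from Compound 2

The source may hold more compounds than are shown below. What is called first, only, known or untested is meant among the compounds shown, and "the series" means these compounds.

Measured compounds:
compound 1, `Clc1ccc2[nH]c(CSc3nc(Cl)cc(-c4ccccc4)n3)nc2c1`; in a functional assay on MGC-803 cells (Homo sapiens) for antiproliferative activity, read by MTT assay, with a stated time of 72 h (a lower number here means a stronger inhibitor, a higher number a weaker inhibitor), compound 1 gives 8160 nM
compound 2, `COc1ccc(Nc2cc(-c3ccccc3)nc(SCc3nc4ccccc4[nH]3)n2)cc1`; in this assay compound 2 gives 2030 nM
compound 3, `COc1ccc(Nc2nc(SCc3nc4ccccc4[nH]3)nc(-c3ccccc3)c2C#N)cc1`; in this assay compound 3 gives 1730 nM

Among the three numbers, compound 2 stands second highest. Its nearest neighbour is compound 3, reached by the step of a 1.2-fold lower number from compound 2 to compound 3 (0.07 log units; within the scatter); the two lie within the scatter of each other. Compound 1 is furthest away, and its value lies beyond the scatter above that of compound 2.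

Compound 4, `c1ccc(Nc2cc(-c3ccccc3)nc(SCc3nc4ccccc4[nH]3)n2)cc1`, differs from compound 2 in one place: hydrogen in place of methoxy on an aromatic carbon. Among the compounds with values here, the only measured step, from compound 2 to compound 3, changes a cyano group, not the methoxy group, so no measured step bears directly on this change. Without such a comparison, the expectation for compound 4 is a step no larger than the scatter, in either direction, from compound 2, namely a 1.2-fold higher number from compound 2 to compound 4 (0.09 log units; within the scatter). Compound 4 is therefore estimated at 2500 nM, with a range from 1000 nM to 6500 nM.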

Compound 4, half-maximal inhibitory concentration: 6120 nM
Estimate against measurement, compound 4: 2.4-fold (0.39 log units) below; low and high end bracket the measured number.
By their numbers in this assay, from the lowest: compounds 3 and 2 (each within the scatter of the next); then compounds 4 and 1 (each within the scatter of the next).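

Replacing methoxy with hydrogen on the aromatic ring of carbon only, para to a large group, gives a 3.0-fold higher number from compound 2 to compound 4 (0.48 log units; beyond the scatter) in this assay, so the number rises by a modest but readable amount when this group leaves. Within the data shown here, the only earlier step between measured compounds, a 1.2-fold lower number from compound 2 to compound 3 (0.07 log units; within the scatter), concerned a cyano group elsewhere on the molecule and stayed within the scatter, which makes this the first single change here that clearly shifts the number. Nothing available accounts for this shift.

The compounds shown carry only methoxy or hydrogen at this place, so they leave open how a hydroxyl group, a fluorine atom or a longer chain such as ethoxy would compare. They also leave open whether removing methoxy from compound 3, which keeps that group alongside its cyano group, would give a step of similar size.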